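Swapping cyclopropyl for 2-(pyridin-4-yl)ethenyl on a shared core

The compounds below may be only part of what the source reports. "The series", "measured", "known", "first", "only" and "open" are said of these compounds alone.

Of the compounds shown here, three sharing one core have been tested in a functional assay on A549 cells (Homo sapiens) for cytotoxicity, read by MTT assay, with a stated time of 48 h; on this read-out higher numbers stand for weaker inhibition and lower numbers for stronger inhibition. Compound 3 (`C=C1C(=O)O[C@H]2CC3=C[C@H](C/C(C)=C/[C@@H](OC(=O)C4CC4)[C@H]12)OC3=O`) gives 3200 nM, and compound 2 (`C=C1C(=O)O[C@H]2CC3=C[C@H](C/C(C)=C/[C@@H](OC(=O)/C=C/c4ccccc4)[C@H]12)OC3=O`) gives 4800 nM. The step between them, a 1.5-fold lower number from compound 2 to compound 3 (0.18 log units; within the scatter), means that these two cannot be told apart. Compound 1 (`C=C1C(=O)O[C@H]2CC3=C[C@H](C/C(C)=C/[C@@H](OC(=O)c4ccc([N+](=O)[O-])cc4)[C@H]12)OC3=O`) reads > 10000 nM, which is a limit of the assay. Measured against that limit, the steps are an at least 2.0-fold lower number from compound 1 to compound 2 (0.31 log units; beyond the scatter) and an at least 3.1-fold lower number from compound 1 to compound 3 (0.49 log units; beyond the scatter).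

Compound 4 (`C=C1C(=O)O[C@H]2CC3=C[C@H](C/C(C)=C/[C@@H](OC(=O)/C=C/c4ccncc4)[C@H]12)OC3=O`) differs from compound 3 by 2-(pyridin-4-yl)ethenyl in place of cyclopropyl on a carbonyl carbon. The closest guide is compound 2, which carries 2-phenylethenyl on that carbonyl carbon and sits within the scatter of compound 3, as a 1.5-fold lower number from compound 2 to compound 3 (0.18 log units; within the scatter) shows. Among the compounds with values here, no tested compound carries 2-(pyridin-4-yl)ethenyl, so the range must stay wide. In this assay, the expected change is a 1.4-fold higher number from compound 3 to compound 4 (0.15 log units; within the scatter), which would be no step beyond the scatter. For compound 4 the estimated value is 4500 nM, with an expected range of 1800 nM to 10000 nM.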

Compound 4, half-maximal inhibitory concentration: 4000 nM
Estimate against measurement, compound 4: 1.1-fold (0.05 log units) above; the range from low to high includes it.
By their numbers in this assay, from the lowest: compounds 3, 4 and 2 (each within the scatter of the next). At a limit, above all of these: compound 1.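

In this assay, pyridin-4-yl in place of phenyl gives a 1.2-fold lower number from compound 2 to compound 4 (0.08 log units; within the scatter), and going from cyclopropyl, with 3 heavy atoms, to 2-(pyridin-4-yl)ethenyl, with 8, gives a 1.3-fold higher number from compound 3 to compound 4 (0.10 log units; within the scatter), so neither the ring nitrogen nor the larger group makes a difference that can be read at this carbonyl carbon. Only 4-nitrophenyl stands apart from the other three groups, with an at least 2.5-fold lower number from compound 1 to compound 4 (0.39 log units; beyond the scatter). That step is a bound and not an exact size, since compound 1 reads a limit and not a number: the limit of > 10000 nM in this assay, at which 1 of the 4 values shown sits.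

From the compounds shown here alone, whether an amine or a carboxylic acid on this carbonyl carbon would move the number beyond the scatter remains open. So does whether a longer chain carrying the pyridine ring would bring the number clearly below those of compounds 2, 3 and 4.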